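The source may report more compounds than this note shows. Statements on the series, on what has been measured and on what is new or still open speak of the compounds shown alone.

Measured so far in a functional assay on HL-60 cells (Homo sapiens) for cytotoxicity, read by WST assay, with a stated time of 48 h; a higher number here means that more compound is needed for the effect, a lower number that less compound is needed:

compound 1, `O=C1OC[C@H](Cc2ccccc2F)[C@H]1Cc1ccc(Cl)c(Cl)c1`, gives 28000 nM;
compound 2, `O=C1OC[C@H](Cc2cccc(O)c2)[C@H]1Cc1ccc(Cl)c(Cl)c1`, gives 48000 nM;
compound 3, `Fc1ccccc1C[C@H]1COC[C@@H]1Cc1ccc(Cl)c(Cl)c1`, gives 51000 nM.

Compounds 1 and 2 share one core, and compound 3 carries a second core; the difference between the two cores is not broken down here, and the numbers of compound 1 and compound 3 lie within the scatter of each other, so they show no order. One change is seen twice among these compounds. Within the first core it is 3-hydroxyphenyl in place of 2-fluorophenyl on a saturated chain carbon bound to a saturated ring carbon, and the step it made was a 1.7-fold higher number from compound 1 to compound 2 (0.23 log units; within the scatter), so this change left the number essentially where it was. Compound 4, `Oc1cccc(C[C@H]2COC[C@@H]2Cc2ccc(Cl)c(Cl)c2)c1`, is the not yet measured compound that carries the same change on the second core: 3-hydroxyphenyl in place of 2-fluorophenyl on a saturated chain carbon bound to a saturated ring carbon. The place is described in the same words in both cases. In this assay, within the data shown here, the step from compound 3 to compound 4 is therefore expected to be about a 1.5-fold higher number from compound 3 to compound 4 (0.17 log units; within the scatter), resting on the single earlier step of a 1.7-fold higher number from compound 1 to compound 2 (0.23 log units; within the scatter) and on the small number of compounds. Compound 4 is expected to give about 75000 nM in this assay, with a range from 30000 nM to 200000 nM.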

Compound 4, half-maximal effective concentration: 31000 nM
Compound 4: middle estimate off by 2.4-fold (0.38 log units), on the high side; low and high end bracket the measured number.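

In this assay, putting 3-hydroxyphenyl in place of 2-fluorophenyl on the second core gave a 1.6-fold lower number from compound 3 to compound 4 (0.22 log units; within the scatter), so taken alone this step left the number essentially where it was. Set beside the same change on the first core, the step did not carry over unchanged, since the two steps point in opposite directions and the gap between them is larger than scatter alone would give: the same change on two cores in this assay, a 1.7-fold higher number (0.23 log units; within the scatter) from compound 1 to compound 2 and a 1.6-fold lower number (0.22 log units; within the scatter) from compound 3 to compound 4, 2.8-fold (0.45 log units) apart, beyond the scatter of two such steps. Among these compounds, this shows that, for this pair of cores, the step seen on one core was not a safe guide to the step on the other, but it does not show why the cores differ, and with only one step per core and each step small, it sets no rule for the series.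

On these data alone, whether an amine, a carboxylic acid or a longer chain at the same place would also behave differently on the two cores stays open. Also open, as far as these compounds go, is whether the gap between the two steps would appear again with other groups in this place.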